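Ortho-substituted anilides in the orexin receptor type 2 series

The compounds below may be only part of what the source reports. "The series", "measured", "known", "first", "only" and "open" are said of these compounds alone.

Among the measured compounds shown here, compound 1 `O=C(Nc1ccccc1)[C@@H]1CCCN1C(=O)CSc1nc2ccccc2[nH]1` is the weakest-bound member of the three compounds measured so far. In an assay on CHO cells for displacement of a labelled ligand from Orexin receptor type 2 (Homo sapiens) (on this read-out higher numbers stand for weaker inhibition and lower numbers for stronger inhibition), compound 1 gives 560 nM. The two compounds that carry a substituent on the anilide ring sit far from it: compound 2 `Cn1c(SCC(=O)N2CCC[C@H]2C(=O)Nc2ccccc2-c2ccccc2)nc2ccccc21` gives 0.2 nM in this assay, and compound 3 `O=C(Nc1ccccc1-n1cccc1)[C@@H]1CCCN1C(=O)CCc1nc2ccccc2[nH]1` gives 11 nM. Both gaps to compound 1 lie beyond the usual scatter. Compound 2 and compound 3 differ from compound 1 in more than one place, so no single-point comparison exists among the measured compounds.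

Compound 4 `O=C(Nc1ccccc1Oc1ccccc1)[C@@H]1CCCN1C(=O)CSc1nc2ccccc2[nH]1` is the next compound for this assay. It differs from compound 1 in one place: phenoxy in place of hydrogen on an aromatic carbon. The new group sits ortho to a large group, the same kind of position that carries the aryl substituents of compound 2 and compound 3.

Given the distance of compound 3 at 11 nM and compound 2 at 0.2 nM from compound 1, a large step toward stronger inhibition is expected, and the step from compound 1 to compound 4 is estimated at a 110-fold lower number from compound 1 to compound 4 (2.05 log units; beyond the scatter). For compound 4 the estimate in this assay is 5 nM, expected to fall between 0.8 nM and 30 nM.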

Compound 4, inhibition constant: 3 nM
Beside the measured number, compound 4's estimate is 1.7-fold (0.22 log units) above it; measured number inside the range.
By their numbers in this assay, from the lowest: compound 2; then compound 4; then compound 3; then compound 1.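

In this assay, among the compounds shown here, phenoxy in place of hydrogen on an aromatic carbon, ortho to a large group, gives a 190-fold lower number from compound 1 to compound 4 (2.27 log units; beyond the scatter), which makes this the first step that can be read at a single place. The large gain therefore needs no other structural difference: on the core of compound 1, this one substituent on the six-membered aromatic ring is enough, whereas the gaps from compound 1 to compound 2 and compound 3 come with changes in more than one place and cannot be assigned to the substituent alone. No evidence at hand bears on why the step is this large.

From the compounds shown here alone, it remains open whether this gain needs the phenoxy group as such, or whether methoxy, a phenyl ring attached without the oxygen, an amine or a carboxylic acid at the same place on the core of compound 1 would give a step of similar size. Also open is how phenoxy behaves on another carbon of the same ring, so the shown compounds do not yet tie the gain to this position.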